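Cyclopentyl for cyclohexyl on an amide nitrogen

The source may hold more compounds than are shown below. What is called first, only, known or untested is meant among the compounds shown, and "the series" means these compounds.

Measured compounds:
Compound 1 `CCC(C)C(NC(=O)n1nnc2ccccc21)C(=O)NC1CCCCC1` — 80 ug/mL
Compound 2 `O=C1NC(c2ccccc2)C(=O)N1Cc1ccccc1` — 100 ug/mL
Compound 3 `CC(C)C1NC(=O)N(C2CCCCC2)C1=O` — >= 100 ug/mL, a limit of the assay

In a functional assay on HEL cells (Homo sapiens) for cytotoxicity (on this read-out higher numbers stand for lower toxicity in this test and lower numbers for higher toxicity in this test), compound 1 gives 80 ug/mL. This is the lowest of the two numbers that are reported, but the nearest of them, compound 2 at 100 ug/mL, lies within the scatter of compound 1, so the two cannot be placed in any order. Compound 3 gives no number at all; its result is the limit of >= 100 ug/mL in this assay, at which 1 of the 3 values shown sits, and nothing more can be read from it.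

Compound 4 `CCC(C)C(NC(=O)n1nnc2ccccc21)C(=O)NC1CCCC1` is not yet measured. It differs from compound 1 in one place: cyclopentyl in place of cyclohexyl on an amide-type nitrogen, the same change reading cyclohexylamino to cyclopentylamino one bond further out. For the measured compounds named here, no measured pair in this set shows what such a change does, so the expected step of no change at the digits printed from compound 1 to compound 4 (within the scatter) is none beyond the scatter. The estimate for compound 4 in this assay is therefore 80 ug/mL, with a range from 40 ug/mL to 160 ug/mL.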

Compound 4, minimum cytotoxic concentration: >= 80 ug/mL
Compound 4: a limit, no number; the forecaster's own chance of this, stated with the estimate: 25%; the middle value lies on the limit itself.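

The set now holds one step at this place: in this assay, cyclopentyl in place of cyclohexyl on an amide-type nitrogen gives a number no lower from compound 1 to compound 4 (the limit leaves the size open). For the compounds shown here, the result for compound 4 is a limit and not a number: the limit of >= 80 ug/mL in this assay, at which 1 of the 4 values shown sits. Cyclopentyl on this nitrogen therefore gives no sign of higher toxicity in this test than cyclohexyl, which no earlier compound could show.

The compounds shown leave open how large the step is, and whether the two rings differ at all in this test. They also leave open what a phenyl group, a tert-butyl group or a cyclohexyl ring carrying an amine would do on this amide-type nitrogen.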